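A Pyrazole Ring Replaces Fluorine on the Aryl Arm

The source may report more compounds than this note shows. Statements on the series, on what has been measured and on what is new or still open speak of the compounds shown alone.

Compound 1 `COc1cc(-c2ccnc3cc(-c4ccc(F)cc4)nn23)cc(OC)c1OC`: 4540 nM
Compound 2 `COc1cc(-c2ccnc3cc(-c4cn(C)c5ccccc45)nn23)cc(OC)c1OC`: 185 nM
Compound 3 `COc1ccc(-c2cc3nccc(-c4cc(OC)c(OC)c(OC)c4)n3n2)cc1F`: 3950 nM

Of the compounds shown here, three sharing one core have been measured in a functional assay on B16-F0 cells (Mus musculus) for inhibition, read by CCK-8 assay, with a stated time of 48 h; a higher number here means a weaker inhibitor, a lower number a stronger inhibitor. Compound 1 gives the highest of the three numbers. Compound 3 sits alongside it: the step of a 1.1-fold lower number from compound 1 to compound 3 (0.06 log units; within the scatter) lies within the scatter. Compound 2 is far away, the step of a 25-fold lower number from compound 1 to compound 2 (1.39 log units; beyond the scatter) being the only large one in the set.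

The next compound is compound 4 `COc1cc(-c2ccnc3cc(-c4ccc(-c5cnn(C)c5)cc4)nn23)cc(OC)c1OC`. Relative to compound 1 it carries one change: 1-methyl-1H-pyrazol-4-yl in place of fluoro on an aromatic carbon.

Among the compounds with values here, two measured steps bear on it. Both replace the aryl arm of compound 1. A small change, the step of a 1.1-fold lower number from compound 1 to compound 3 (0.06 log units; within the scatter), moved nothing beyond the scatter, while a larger change, the step of a 25-fold lower number from compound 1 to compound 2 (1.39 log units; beyond the scatter), moved the number a long way lower. The change to compound 4 adds a whole ring, so the step is expected to be a 3.0-fold lower number from compound 1 to compound 4 (0.48 log units; beyond the scatter), though its size is uncertain. Compound 4 is therefore estimated at 1500 nM, with a range from 300 nM to 8000 nM.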

Compound 4, half-maximal inhibitory concentration: 1240 nM
Estimate against measurement, compound 4: 1.2-fold (0.08 log units) above, within the range that was stated.
By their numbers in this assay, from the lowest: compound 2; then compound 4; then compounds 3 and 1 (each within the scatter of the next).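

Up to this point, only replacements of the whole aryl arm had been seen; here the phenyl ring stays, and only the fluoro group on it gives way to 1-methyl-1H-pyrazol-4-yl, para to a large group. This carbon accepts an added five-membered aromatic ring, and a 3.7-fold lower number from compound 1 to compound 4 (0.56 log units; beyond the scatter) shows a modest change beyond the scatter in this assay, yet compound 4, at 1240 nM, still stands well above compound 2, at 185 nM. Nothing available explains this step.

The compounds shown leave open how much of the step comes from losing fluoro and how much from the entering ring. They also leave open whether an amine, a carboxylic acid or a longer chain at this carbon would lower the number further.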